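Aryl substituent changes and cell tolerance in the series

The source may hold more compounds than are shown below. What is called first, only, known or untested is meant among the compounds shown, and "the series" means these compounds.

Compound 1, `CC(C)c1ccc(-n2cc(-c3cn([C@H]4C[C@H](O)[C@@H](CO)O4)c(=O)[nH]c3=O)nn2)cc1`: in an ADME assay on HEL cells (Homo sapiens) for cytotoxicity, read by cell counting, with a stated time of 3 days (a higher number here means that more compound is tolerated, a lower number that less compound is tolerated), compound 1 gives > 240000 nM, which is a limit of the assay.
Compound 2, `CC(C)(C)c1ccc(-n2cc(-c3cn([C@H]4C[C@H](O)[C@@H](CO)O4)c(=O)[nH]c3=O)nn2)cc1`: in this assay compound 2 gives 230000 nM.
Compound 3, `CSc1ccc(-n2cc(-c3cn([C@H]4C[C@H](O)[C@@H](CO)O4)c(=O)[nH]c3=O)nn2)cc1`: in this assay compound 3 gives > 230000 nM, a limit of the assay.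

Compound 3 therefore stands at a limit (the limit of > 230000 nM in this assay, at which 1 of the 3 values shown sits), and one of the other values, compound 1, also sits at a limit (the limit of > 240000 nM in this assay, at which 1 of the 3 values shown sits). Going by the values given here, the only fully readable step is an at least 1.0-fold lower number from compound 1 to compound 2 (0.01 log units; that floor lies within the scatter), which lies within the scatter. The step that the two limits leave unreadable from compound 1 to compound 3 cannot be sized, and a number no lower from compound 2 to compound 3 (the limit leaves the size open) is open in size.

Compound 4 is `O=c1[nH]c(=O)n([C@H]2C[C@H](O)[C@@H](CO)O2)cc1-c1cn(-c2ccc(Oc3ccccc3)cc2)nn1`, and it differs from compound 3 by phenoxy in place of methylsulfanyl on an aromatic carbon. Among the compounds with values here, none of the measured steps involves a phenoxy group, so none bears directly on this change; all three measured compounds sit at or near the same high tolerance. On that basis the step of an at least 1.0-fold lower number from compound 3 to compound 4 (0.01 log units; that floor lies within the scatter) is expected to be none beyond the scatter. Compound 4 is therefore estimated at 220000 nM in this assay, with a range from 90000 nM to 500000 nM.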

Compound 4, minimum cytotoxic concentration: 130000 nM
The estimate for compound 4 lay 1.7-fold (0.23 log units) above the measured number; the range from low to high includes it.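

Going by these compounds alone, with phenoxy on the aromatic carbon para to a large group, the series now carries a six-membered aromatic ring of carbon only at this position, and this assay still shows no step that clears the scatter: a 1.8-fold lower number from compound 2 to compound 4 (0.25 log units; within the scatter). The other two steps, an at least 1.7-fold lower number from compound 3 to compound 4 (0.24 log units; that floor lies within the scatter) and an at least 1.8-fold lower number from compound 1 to compound 4 (0.26 log units; that floor lies within the scatter), are floors and also stay within the scatter. Compound 3 and compound 1 both stand at limits of the assay, so the full size of these two steps cannot be read.

From the compounds shown here alone, whether an amine or a carboxylic acid at this position would give a step beyond the scatter remains open. Also open, going by these compounds, is whether a longer chain in place of phenoxy would leave cell tolerance as it stands in compound 4.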